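The source may hold more compounds than are shown below. What is called first, only, known or untested is meant among the compounds shown, and "the series" means these compounds.

Working notes on the series. The shared core of compound 1 `Cc1cccc2c(=O)c(-c3nn[nH]n3)c[nH]c12` carries a methyl on the aromatic ring; compound 2 `CCc1cccc2c(=O)c(-c3nn[nH]n3)c[nH]c12` carries an ethyl there, and compound 3 `CC(C)c1cccc2c(=O)c(-c3nn[nH]n3)c[nH]c12` an isopropyl. Within the data shown here, in a functional assay on the whole organism (strain Sprague-Dawley) for inhibition, with Rattus norvegicus as the target (on this read-out higher numbers stand for an effect only at larger amounts of compound and lower numbers for an effect already at smaller amounts), compound 3 gives 10 mg/kg, the only number among the three values shown. Compound 1 gives in this assay only a limit, > 10 mg/kg. Compound 2 also gives only a limit in this assay, > 25 mg/kg. Among the measured compounds shown here, the one readable step is an at least 2.5-fold lower number from compound 2 to compound 3 (0.39 log units; beyond the scatter); the steps a step that the two limits leave unreadable from compound 1 to compound 2 and a number no higher from compound 1 to compound 3 (the limit leaves the size open) stay open because of the limit of > 10 mg/kg in this assay, at which 1 of the 3 values shown sits, and (the limit of > 25 mg/kg in this assay, at which 1 of the 3 values shown sits).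

Compound 4 `CC(C)Oc1cccc2c(=O)c(-c3nn[nH]n3)c[nH]c12` differs from compound 3 in one place: isopropoxy in place of isopropyl on an aromatic carbon. For the measured compounds named here, none of the measured steps adds a hydrogen-bond acceptor; each of them only lengthens or branches a saturated chain on the aromatic carbon, so no measured step bears directly on this change, and the step of an at least 2.5-fold lower number from compound 2 to compound 3 (0.39 log units; beyond the scatter) is the only indication that alterations at this position are read at all in this assay. Compound 4 is therefore expected to give 10 mg/kg in this assay, with a range from 3 mg/kg to 30 mg/kg. The step of no change at the digits printed from compound 3 to compound 4 (within the scatter) is expected to stay within the scatter, in no set direction.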

Compound 4, minimum effective dose: 1.25 mg/kg
The estimate for compound 4 lay 8.0-fold (0.90 log units) above the measured number, outside the stated range (below it).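

In this assay, an 8.0-fold lower number from compound 3 to compound 4 (0.90 log units; beyond the scatter), so this position responds to a change of a different kind from the saturated chains: isopropoxy brings a hydrogen-bond acceptor that isopropyl lacks, and the number moves beyond the scatter. Against the smaller groups, an at least 20-fold lower number from compound 2 to compound 4 (1.30 log units; beyond the scatter), and an at least 8.0-fold lower number from compound 1 to compound 4 (0.90 log units; beyond the scatter), which leaves compound 4 with the lowest number of the four. Both of these sizes are floors, and the other steps from compound 1 remain unreadable, because they rest on the values of compound 1 and compound 2, which are limits and not numbers: the limit of > 10 mg/kg in this assay, at which 1 of the 4 values shown sits; the limit of > 25 mg/kg in this assay, at which 1 of the 4 values shown sits.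

The compounds shown leave open whether the lower number goes with the oxygen itself or with the isopropoxy group as a whole; a methoxy, an ethoxy or an isopropylamino group on the same aromatic carbon would separate the two. Also open, on these data alone, is how far the trend carries to a longer chain on the oxygen, such as butoxy, or to a cyclopentyloxy group.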